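This account rests on a few compounds, and the source may have more. Where it says the series, first, only, none or still open, it means among the compounds named here.

Compound 1 `COc1cc(NC(=O)c2cnc(C)cn2)c2ncccc2c1` is the starting point of this small set. In a functional assay on BXPC-3 cells (Homo sapiens) for inhibition, read by MTT assay, with a stated time of 72 h (on this read-out lower numbers stand for stronger inhibition and higher numbers for weaker inhibition), compound 1 gives 6700 nM. Compound 2 `COc1cc(NC(=O)c2ncccn2)c2ncccc2c1` carries pyrimidin-2-yl in place of 5-methylpyrazin-2-yl on a carbonyl carbon. In this assay compound 2 gives > 10000 nM, which is a limit of the assay and not a number, as noted in the limit of > 10000 nM in this assay, at which 1 of the 3 values shown sits. The step is an at least 1.4-fold higher number from compound 1 to compound 2 (0.17 log units; that floor lies within the scatter), so it cannot be said how far the two truly lie apart.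

Compound 3 `Cc1cnc(C(=O)Nc2cc(OCCC3CCN(C(=O)OC(C)(C)C)CC3)cc3cccnc23)cn1` keeps the 5-methylpyrazin-2-yl carbonyl amide of compound 1 but has a different core; how the two cores differ is not broken down here. In this assay compound 3 gives 9330 nM, and against compound 1 the two numbers lie within the usual scatter, so no order between them can be stated.

Compound 4 `CC(C)(C)OC(=O)N1CCC(CCOc2cc(NC(=O)c3ncccn3)c3ncccc3c2)CC1` is the counterpart of compound 3, again with pyrimidin-2-yl in place of 5-methylpyrazin-2-yl on a carbonyl carbon; the place is the same in both pairs, so this is the same change as between compound 1 and compound 2. The estimated step of a 1.6-fold higher number from compound 3 to compound 4 (0.21 log units; within the scatter) is expected to be at least as large as the earlier one, an at least 1.4-fold higher number from compound 1 to compound 2 (0.17 log units; that floor lies within the scatter), since compound 3 already gives 9330 nM. For compound 2 the same change led to a value that is a limit of the assay. Compound 4 is therefore expected to give about 15000 nM, with a likely span from 8000 nM to 40000 nM, and quite possibly only a limit will be reported.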

Compound 4, half-maximal inhibitory concentration: > 10000 nM
Compound 4: only a limit was reported; the forecaster's own chance of this, stated with the estimate: 70%; the middle value does not contradict the limit.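

In this assay compound 4 gives > 10000 nM, which is a limit of the assay and not a number. Read as a step, this is an at least 1.0-fold higher number from compound 3 to compound 4 (0.03 log units; that floor lies within the scatter), a floor and no more, so the size of the change on this core stays unknown and the comparison with the other core yields no measure of how well the change carries over: the same change on two cores in this assay, an at least 1.4-fold higher number (0.17 log units; that floor lies within the scatter) from compound 1 to compound 2 and an at least 1.0-fold higher number (0.03 log units; that floor lies within the scatter) from compound 3 to compound 4; the limit leaves it open whether they differ What the two pairs do show is that pyrimidin-2-yl in place of 5-methylpyrazin-2-yl on a carbonyl carbon ended at the same limit on both cores, but this does not show that the change has the same effect on each core, nor how far either pyrimidin-2-yl compound truly lies from its partner: the limit of > 10000 nM in this assay, at which 2 of the 4 values shown sit.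

The compounds shown leave open whether a free amine or a carboxylic acid at the end of the chain in place of the tert-butyl carbamate, or a longer chain, would give a number clear of the limit for the pyrimidin-2-yl amides. They also leave open whether a phenyl group on the carbonyl carbon would allow the same change to be followed in numbers rather than limits.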